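Removing the chloro from the urea aryl ring

The source may hold more compounds than are shown below. What is called first, only, known or untested is meant among the compounds shown, and "the series" means these compounds.

Of the compounds shown here, three sharing one core have been tested in a functional assay on NCI-H322M cells (Homo sapiens) for inhibition, read by sulforhodamine B assay, with a stated time of 48 h, tested at 10 uM; on this read-out higher numbers stand for a weaker effect at the one concentration tested and lower numbers for a stronger effect. Compound 1 `O=C(Nc1cccc(-n2cc(-c3ccncc3)c(-c3cc(O)cc(Cl)c3)n2)c1)Nc1ccc(Cl)c(C(F)(F)F)c1` gives 45%. Compound 2 `O=C(Nc1cccc(-n2cc(-c3ccncc3)c(-c3cc(O)cc(Cl)c3)n2)c1)Nc1ccc(Cl)c(Cl)c1` gives 19.5%, and compound 3 `COc1cc(Cl)cc(-c2nn(-c3cccc(NC(=O)Nc4ccc(Cl)c(C(F)(F)F)c4)c3)cc2-c2ccncc2)c1` gives 18.7%. Compound 3 thus stands lowest of the three numbers, close to compound 2 and clearly below compound 1; the step of a number 26.3 percentage points lower from compound 1 to compound 3 (beyond the scatter) lies beyond the scatter, as does a number 25.5 percentage points lower from compound 1 to compound 2 (beyond the scatter).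

Compound 4 `COc1cc(Cl)cc(-c2nn(-c3cccc(NC(=O)Nc4cccc(C(F)(F)F)c4)c3)cc2-c2ccncc2)c1` differs from compound 3 in one place: hydrogen in place of chloro on an aromatic carbon. Within the data shown here, no measured step shows this exact change. The step from compound 1 to compound 2, a change on the same aromatic ring, moved the read-out by a number 25.5 percentage points lower from compound 1 to compound 2 (beyond the scatter), which shows that the substituents on this ring can shift the result by a modest amount. The other step, a number 26.3 percentage points lower from compound 1 to compound 3 (beyond the scatter), concerns the oxygen on the far ring and does not bear on the chloro.

Because a number 25.5 percentage points lower from compound 1 to compound 2 (beyond the scatter) shows that this ring is sensitive, a modest change is expected; losing the chloro is expected to weaken the effect, giving an upward step of a number 21.3 percentage points higher from compound 3 to compound 4 (beyond the scatter). Compound 4 is therefore estimated at 40%, within a range from 15% to 70%.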

Compound 4, a percentage reported as activity, at one concentration (the size of the read-out at that concentration, not a potency): 26.2%
Beside the measured number, compound 4's estimate is 13.8 percentage points above it, and the stated range covers the measured number.
By their numbers in this assay, from the lowest: compounds 3, 2 and 4 (each within the scatter of the next); then compound 1.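

In this assay, replacing the chloro of the 4-chloro-3-(trifluoromethyl)phenyl group with hydrogen gives a number 7.5 percentage points higher from compound 3 to compound 4 (within the scatter), so on this aromatic carbon, ortho to a trifluoromethyl group, the loss of the chloro cannot be told apart from the usual scatter of the read-out. The earlier step on this ring, a number 25.5 percentage points lower from compound 1 to compound 2 (beyond the scatter), involved chloro taking the place of trifluoromethyl, and the sensitivity it revealed does not carry over to this chloro, at least between the two compounds compared here. The data available offer no explanation for this outcome.

From the compounds shown here alone, this single step was read with the methylated oxygen on the far ring, so it remains open whether the chloro could be lost with as little consequence from compound 1, which carries the free hydroxyl there. Also open, going by these compounds, is how this position would respond to a group other than chloro or hydrogen, such as an amine or a carboxylic acid, and whether the trifluoromethyl group could be removed along with the chloro.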